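Halogen swap on the aryl imine: cytotoxicity working notes

A few compounds are considered here, and "the series" means these few. Any claim that something is new, unique, unknown or untested is made for them only; others in the source may bear on it.

Compound 1, `Fc1ccc(/C=N/c2sc3c(c2-c2nc4ccccc4s2)CCC3)cc1`, and compound 2, `Clc1ccc(/C=N/c2sc3c(c2-c2nc4ccccc4s2)CCC3)cc1`, share one core; compound 3, `Fc1ccccc1/C=N/c1sc2c(c1-c1nc3ccccc3s1)CCCC2`, and the not yet measured compound 4, `Clc1ccccc1/C=N/c1sc2c(c1-c1nc3ccccc3s1)CCCC2`, share another. How the core of compound 3 differs from the core of compound 1 is not broken down here. In an ADME assay on HeLa cells (Homo sapiens) for cytotoxicity, read by MTT assay, with a stated time of 72 h (on this read-out lower numbers stand for higher toxicity in this test and higher numbers for lower toxicity in this test), compound 1 gives 372 ug/mL, compound 2 gives 380 ug/mL and compound 3 gives 426 ug/mL; all three lie within the scatter of one another. The change from compound 1 to compound 2 is chloro in place of fluoro on an aromatic carbon. The step it made was a 1.0-fold higher number from compound 1 to compound 2 (0.01 log units; within the scatter). The change from compound 3 to compound 4 is chloro in place of fluoro on an aromatic carbon. It is the same kind of change, but the place is not identical: para to a large group in the first pair, ortho to a large group in the second. Since the earlier step of a 1.0-fold higher number from compound 1 to compound 2 (0.01 log units; within the scatter) stayed within the scatter, an equally small step is expected here, a 1.0-fold higher number from compound 3 to compound 4 (0.00 log units; within the scatter), again within the scatter. Compound 4 is therefore estimated at 430 ug/mL in this assay, with a likely range from 290 ug/mL to 640 ug/mL.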

Compound 4, half-maximal cytotoxic concentration: 407 ug/mL
For compound 4 the middle estimate is 1.1-fold (0.02 log units) above the measured one; the measured number falls inside the stated range.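

In this assay, the change from 2-fluorophenyl to 2-chlorophenyl gives a 1.0-fold lower number from compound 3 to compound 4 (0.02 log units; within the scatter), so this swap leaves the number within the scatter on this core as well. Set beside the earlier pair, the two steps agree: the same change on two cores in this assay, a 1.0-fold higher number (0.01 log units; within the scatter) from compound 1 to compound 2 and a 1.0-fold lower number (0.02 log units; within the scatter) from compound 3 to compound 4, 1.1-fold (0.03 log units) apart, within the scatter of two such steps. This shows that chloro in place of fluoro carried from one core to the other as a step within the scatter, but only for two pairs that differ in both core and halogen position, so the influence of core and position cannot be separated, and a step with no readable size does not show how a larger one would transfer.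

The compounds shown leave open whether a group other than a halogen on the same aromatic ring, such as an amine, a carboxylic acid or a methoxy group, would move the number beyond the scatter. Also open, going by these compounds, is whether either halogen would behave the same way at the other position on each core.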